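Swapping nitro for trifluoromethyl on compound 3

This account rests on a few compounds, and the source may have more. Where it says the series, first, only, none or still open, it means among the compounds named here.

Of the compounds shown here, three have so far been tested in a functional assay on A2780 cells (Homo sapiens) for inhibition, with a stated time of 72 h; a higher number here means a weaker inhibitor, a lower number a stronger inhibitor. Compound 1 `CC1(C)CCNc2ccc(NC(=S)Nc3ccc([N+](=O)[O-])cc3)cc21` gives 7100 nM, and compound 2 `CC1(C)CCNc2ccc(NC(=S)Nc3ccc(C(F)(F)F)cc3)cc21` gives 6000 nM. Compound 3 `CN1c2ccc(NC(=O)Nc3ccc([N+](=O)[O-])cc3)cc2C(C)(C)C(=O)C1(C)C` gives 3800 nM, which lies within the usual scatter of both others, so these numbers cannot rank the three.

Compound 4 `CN1c2ccc(NC(=O)Nc3ccc(C(F)(F)F)cc3)cc2C(C)(C)C(=O)C1(C)C` has not yet been measured. It differs from compound 3 in one place: trifluoromethyl in place of nitro on an aromatic carbon. In words, trifluoromethyl stands in place of nitro on an aromatic carbon, para to a large group.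

For the measured compounds named here, only one measured step makes the same swap: a 1.2-fold lower number from compound 1 to compound 2 (0.07 log units; within the scatter), a change within the scatter. That pair has a different core from compound 3, and a single pair establishes no general rule, so it is a guide and not a proof. On this evidence, no shift beyond the scatter is expected in this assay. The expected change is a 1.2-fold lower number from compound 3 to compound 4 (0.06 log units; within the scatter), an estimated step too small for its direction to be relied on. The estimate for compound 4 is 3300 nM, with an expected range from 1700 nM to 6500 nM.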

Compound 4, half-maximal inhibitory concentration: 2580 nM
Compound 4: the middle estimate sits 1.3-fold (0.11 log units) above what was measured; the measured number falls inside the stated range.
By their numbers in this assay, from the lowest: compounds 4, 3, 2 and 1 (each within the scatter of the next, the first and the last beyond it).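

In this assay, the change from nitro to trifluoromethyl at this position now has a second reading on a second core: a 1.5-fold lower number from compound 3 to compound 4 (0.17 log units; within the scatter). Set beside the earlier pair, the step stays small on both cores, and the two steps agree with each other: the same change on two cores in this assay, a 1.2-fold lower number (0.07 log units; within the scatter) from compound 1 to compound 2 and a 1.5-fold lower number (0.17 log units; within the scatter) from compound 3 to compound 4, 1.2-fold (0.10 log units) apart, within the scatter of two such steps. On these two cores, then, a group with hydrogen-bond acceptors gives way to one without any, and the number does not move beyond the scatter, so the two groups cannot be told apart at this position.

The compounds shown carry only these two groups at this position, which leaves open whether something of a different kind there, such as an amine, a carboxylic acid or a longer chain, would shift the number beyond the scatter. Going by these compounds, compound 1 and compound 3 differ in more than one place, so the part played by each difference between the two cores also remains open.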